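Trifluoromethyl in place of trifluoromethoxy: expected cytotoxicity shift

The source may hold more compounds than are shown below. What is called first, only, known or untested is meant among the compounds shown, and "the series" means these compounds.

In an ADME assay on WI-38 cells (Homo sapiens) for cytotoxicity, read by MTT assay, with a stated time of 72 h (a lower number here means a stronger inhibitor, a higher number a weaker inhibitor), compound 3 `O=C(CCc1cccc2c1B(O)OC2)Nc1cccc(-c2cccc(OC(F)(F)F)c2)c1` gives 9800 nM, second highest of three numbers, with compound 1 `O=C(CCc1cccc2c1B(O)OC2)Nc1cccc(-c2cccc(Cl)c2)c1` at 58000 nM and compound 2 `COc1ccc(-c2cccc(NC(=O)CCc3cccc4c3B(O)OC4)c2)cc1` at 1400 nM. Compound 4 `O=C(CCc1cccc2c1B(O)OC2)Nc1cccc(-c2cccc(C(F)(F)F)c2)c1` carries trifluoromethyl in place of trifluoromethoxy on an aromatic carbon. The closest measured change is a 5.9-fold lower number from compound 1 to compound 3 (0.77 log units; beyond the scatter), a modest step with trifluoromethoxy in place of chloro. The large 41-fold lower number from compound 1 to compound 2 (1.62 log units; beyond the scatter) replaces the whole 3-chlorophenyl and bears less directly. In this assay, a small upward step toward compound 1 is therefore expected, possibly not beyond the scatter, estimated as a 1.6-fold higher number from compound 3 to compound 4 (0.21 log units; within the scatter). For compound 4 the estimated value is 16000 nM, with an expected range of 5500 nM to 45000 nM.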

Compound 4, half-maximal inhibitory concentration: 23000 nM
The estimate for compound 4 lay 1.4-fold (0.16 log units) below the measured number; the measured number falls inside the stated range.
By their numbers in this assay, from the lowest: compound 2; then compound 3; then compound 4; then compound 1.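

In this assay, the oxygen of trifluoromethoxy matters at this position: trifluoromethyl alone shifts the number beyond the scatter (a 2.3-fold higher number from compound 3 to compound 4 (0.37 log units; beyond the scatter)). Trifluoromethyl also separates from chloro (a 2.5-fold lower number from compound 1 to compound 4 (0.40 log units; beyond the scatter)), giving three distinct values for these three groups at this position, while the 4-methoxyphenyl compound remains well apart (a 16-fold higher number from compound 2 to compound 4 (1.22 log units; beyond the scatter)). No available evidence explains these differences.

Open, going by these compounds, is how an amine or a carboxylic acid would read at this position. Also open, on these data alone, is whether methoxy alone on this carbon, without the other change in compound 2, would carry that compound's lower number.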